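Two benzyl compounds and a fluoro step

The compounds below may be only part of what the source reports. "The series", "measured", "known", "first", "only" and "open" are said of these compounds alone.

Compound 1 `O=C1/C(=C\c2ccccc2)c2c(ncn2COCc2ccccc2)CCN1Cc1ccccc1` gives 20400 nM
Compound 2 `Cc1ccc(CN2CCc3ncn(COCc4ccccc4)c3/C(=C/c3ccccc3)C2=O)cc1` gives 21200 nM

For the measured compounds named here, both values come from a functional assay on A2780 cells (Homo sapiens) for inhibition, read by MTT assay, with a stated time of 72 h (a higher number here means a weaker inhibitor, a lower number a stronger inhibitor), and lie within the scatter of each other, so compound 2 stands level with compound 1 on the only two numbers available.

The next compound is compound 3 `O=C1/C(=C\c2ccccc2)c2c(ncn2COCc2ccccc2)CCN1Cc1ccc(F)cc1`, which keeps the shared core. It differs from compound 2 as follows: fluoro in place of methyl on an aromatic carbon. This is fluoro in place of methyl on an aromatic carbon, which turns 4-methylbenzyl to 4-fluorobenzyl.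

Going by the values given here, one measured step bears on this change. It is a 1.0-fold higher number from compound 1 to compound 2 (0.02 log units; within the scatter), and it introduced the methyl that now leaves. That step stayed within the scatter, so removing the methyl is not expected to matter much. Among the compounds with values here, no measured compound carries fluoro, so the data say nothing directly about that group, and the forecast rests on this single step.

A step of a 1.1-fold lower number from compound 2 to compound 3 (0.03 log units; within the scatter) is expected, which means none beyond the scatter. For compound 3 the estimated value is 20000 nM, with an expected range of 11000 nM to 38000 nM.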

Compound 3, half-maximal inhibitory concentration: 24800 nM
Beside the measured number, compound 3's estimate is 1.2-fold (0.09 log units) below it; the measured number falls inside the stated range.
By their numbers in this assay, from the lowest: compounds 1, 2 and 3 (each within the scatter of the next).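

Exchanging methyl for fluoro on this aromatic carbon gives a 1.2-fold higher number from compound 2 to compound 3 (0.07 log units; within the scatter), and fluoro in place of hydrogen at the same carbon gives a 1.2-fold higher number from compound 1 to compound 3 (0.08 log units; within the scatter). Hydrogen, methyl and fluoro on the benzyl ring, at the carbon para to a large group, therefore give numbers that cannot be told apart in this assay, whereas the earlier pair covered only hydrogen and methyl, so a change of atom type at this position has now been tested as well. No other measurement is available to explain why the three compounds read alike.

The compounds shown leave open whether a different kind of group at this carbon, such as an amine, a carboxylic acid or a longer chain, would move the number beyond the scatter. They also leave open whether any change elsewhere on the shared core would do so, as all three compounds differ only at this one position.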